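A few compounds are considered here, and "the series" means these few. Any claim that something is new, unique, unknown or untested is made for them only; others in the source may bear on it.

Measured so far:
compound 1 `COc1cc2c(/C=C3/C(=O)Nc4ccc(O)cc43)c(Cl)n(Cc3cc(OC)c(OC)c(OC)c3)c2cc1C` gives 2040 nM
compound 2 `O=C1/C(=C/c2c(Cl)[nH]c3ccccc23)c2ccccc2N1Cc1ccccc1` gives 4900 nM

In a functional assay on cells (Cancer cell lines, Homo sapiens) for cytotoxicity, with a stated time of 48 h (a higher number here means a weaker inhibitor of growth, a lower number a stronger inhibitor of growth), compound 1 holds the lowest of the two numbers; compound 2 sits higher, and that gap is beyond the scatter. Among the compounds with values here, no step between measured compounds differing in one place is available, so the hydroxy group of compound 1 has no measured counterpart in this set. Compound 3 `COc1ccc2c(c1)/C(=C\c1c(Cl)n(Cc3cc(OC)c(OC)c(OC)c3)c3cc(C)c(OC)cc13)C(=O)N2` differs from compound 1 by methyl in place of hydrogen on an oxygen on an aromatic ring. With nothing comparable to lean on, the step is expected to stay small, if anything toward a slightly higher number. The expected shift is a 1.3-fold higher number from compound 1 to compound 3 (0.11 log units; within the scatter). Compound 3 is estimated at 2600 nM, within 1000 nM to 6500 nM.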

Compound 3, concentration for 50% growth inhibition: 16200 nM
Compound 3: the middle estimate sits 6.2-fold (0.79 log units) below what was measured, and the stated range ends below it.
By their numbers in this assay, from the lowest: compound 1; then compound 2; then compound 3.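

In this assay, hydroxy to methoxy on the aromatic ring gives a 7.9-fold higher number from compound 1 to compound 3 (0.90 log units; beyond the scatter), the first measured sign that growth inhibition in this series responds to what sits on this oxygen. A single added methyl is enough to produce a step beyond the scatter. Nothing available bears on the reason for the step.

The compounds shown leave open whether the step follows from losing the hydrogen or from gaining the methyl. From the compounds shown here alone, how an amine or an ethoxy group would read at this place also remains unknown.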